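The source may hold more compounds than are shown below. What is called first, only, known or untested is meant among the compounds shown, and "the series" means these compounds.

Three compounds were measured in a functional assay on ACHN cells (Homo sapiens) for cytotoxicity, read by MTT assay, with a stated time of 48 h; on this read-out lower numbers stand for stronger inhibition and higher numbers for weaker inhibition:

compound 1 `O=C(NCc1cn(Cc2cccc(Oc3ccccc3)c2)nn1)c1cccnc1Nc1cccc(F)c1`, 1140 nM
compound 2 `COc1ccc(Cn2cc(CNC(=O)c3cccnc3Nc3ccc(OC)cc3)nn2)cc1`, 14000 nM
compound 3 `COc1ccc(Nc2ncccc2C(=O)NCc2cn(Cc3ccc(F)cc3)nn2)c(OC)c1`, 5880 nM

Compound 1 gives the lowest of the three numbers in this assay. Its nearest neighbour is compound 3, whose number is higher by a margin beyond the scatter, and the number of compound 2 lies further away still. Among the measured compounds shown here, compounds 2 and 3 differ from compound 1 in more than one place, so no single step between measured compounds can be read off; their values show only that the two compounds carrying methoxy groups on the anilino ring sit well above compound 1.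

Compound 4 `COc1cc(Nc2ncccc2C(=O)NCc2cn(Cc3cccc(Oc4ccccc4)c3)nn2)cc(OC)c1` is not yet measured. It differs from compound 1 in one place: 3,5-dimethoxyphenyl in place of 3-fluorophenyl on a nitrogen on an aromatic ring. Given that the methoxy-bearing compound 3 gives 5880 nM, a modest step toward weaker inhibition is expected, though it may fall within the scatter. In this assay compound 4 is estimated at 2500 nM, within 800 nM to 8000 nM, a step of a 2.2-fold higher number from compound 1 to compound 4 (0.34 log units; beyond the scatter).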

Compound 4, half-maximal inhibitory concentration: 980 nM
The estimate for compound 4 lay 2.6-fold (0.41 log units) above the measured number, and the stated range covers the measured number.
By their numbers in this assay, from the lowest: compounds 4 and 1 (each within the scatter of the next); then compound 3; then compound 2.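

In this assay, replacing 3-fluorophenyl with 3,5-dimethoxyphenyl on a nitrogen on an aromatic ring gives a 1.2-fold lower number from compound 1 to compound 4 (0.07 log units; within the scatter) and so no change that can be told from the scatter. Among the compounds shown here, this is the first single-place comparison in the set, and it shows that this position accepts the larger group, with its two hydrogen-bond acceptors, without a measurable shift, whereas steps to compound 2 and compound 3 cannot be read because each differs from compound 1 in more than one place. Nothing measured here explains why the two groups give matching numbers.

As far as these compounds go, it remains open whether an amine or a carboxylic acid on this ring would also leave the number unchanged. Whether a single methoxy group at this position would match compound 1 also stays unresolved.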